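The source may hold more compounds than are shown below. What is called first, only, known or untested is meant among the compounds shown, and "the series" means these compounds.

Of the compounds shown here, three sharing one core have been measured in a functional assay on GTL 16 cells for antiproliferative activity against GTL 16 cell line (Homo sapiens), read by CCK-8 assay, with a stated time of 72 h; on this read-out higher numbers stand for weaker inhibition and lower numbers for stronger inhibition. Compound 1 `O=C(Nc1cccc(-c2oc3cc(-c4ccc(F)cc4)ccc3c(=O)c2O)c1)c1ccc(F)cc1` gives 14600 nM. Compound 2 `O=C(Nc1cccc(-c2oc3cc(-c4ccc(F)cc4)ccc3c(=O)c2O)c1)c1ccc(F)cc1F` gives 9640 nM. Compound 3 `Cc1ccccc1C(=O)Nc1cccc(-c2oc3cc(-c4ccc(F)cc4)ccc3c(=O)c2O)c1` gives 24800 nM, the highest number of the three; the step of a 1.7-fold higher number from compound 1 to compound 3 (0.23 log units; within the scatter) is within the scatter, whereas the step of a 2.6-fold higher number from compound 2 to compound 3 (0.41 log units; beyond the scatter) lies beyond it, so compound 3 can be called weaker than compound 2 but not than compound 1.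

Compound 4 `O=C(Nc1cccc(-c2oc3cc(-c4ccc(F)cc4)ccc3c(=O)c2O)c1)c1cccc(F)c1` has not yet been measured. It differs from compound 3 in one place: 3-fluorophenyl in place of 2-methylphenyl on a carbonyl carbon. Among the compounds with values here, two measured steps bear on this change, both ending at compound 3: a 1.7-fold higher number from compound 1 to compound 3 (0.23 log units; within the scatter) and a 2.6-fold higher number from compound 2 to compound 3 (0.41 log units; beyond the scatter). Read in reverse, they show that replacing 2-methylphenyl with a fluorine-bearing phenyl on the carbonyl carbon has so far given lower numbers, by a small to modest amount. Within the data shown here, the 3-fluorophenyl of compound 4 is new here, so no measured step covers it exactly, and the two known steps are close to the scatter. A somewhat lower number is therefore expected, a step of a 2.1-fold lower number from compound 3 to compound 4 (0.32 log units; beyond the scatter). Compound 4 is estimated at 12000 nM, with a range from 5000 nM to 30000 nM.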

Compound 4, half-maximal inhibitory concentration: 15800 nM
Compound 4: middle estimate off by 1.3-fold (0.12 log units), on the low side; the range from low to high includes it.
By their numbers in this assay, from the lowest: compounds 2, 1, 4 and 3 (each within the scatter of the next, the first and the last beyond it).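

In this assay, a 1.6-fold lower number from compound 3 to compound 4 (0.20 log units; within the scatter) stays within the scatter, so on this carbonyl carbon, 3-fluorophenyl cannot be told apart from 2-methylphenyl, and a readable gain from this swap is not supported. The other two new steps, a 1.6-fold higher number from compound 2 to compound 4 (0.21 log units; within the scatter) and a 1.1-fold higher number from compound 1 to compound 4 (0.03 log units; within the scatter), also stay within the scatter, so moving from 4-fluorophenyl to 3-fluorophenyl, or from 2,4-difluorophenyl to 3-fluorophenyl, brings no readable change, and compound 4 cannot be separated from any of the other three compounds, even though compound 2 and compound 3 do stand apart from each other. No measurement on hand offers a reason why these groups give such similar numbers.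

Every group shown at this position is a phenyl ring carrying only fluorine or methyl, so it remains open what a phenyl ring bearing a carboxylic acid or a dimethylamino group would give, or what a longer alkyl chain in place of the ring would give. On these data alone, it also remains open whether changes elsewhere, such as replacing the 4-fluorophenyl on the shared core, would move the numbers further than these swaps on the amide side.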